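Benzyl in Place of Phenyl on the Amide Nitrogen

The compounds below may be only part of what the source reports. "The series", "measured", "known", "first", "only" and "open" are said of these compounds alone.

Compound 1 `Nc1sc(-c2ccc(Cl)cc2)c(-c2ccc(Cl)cc2)c1C(=O)Nc1ccccc1`: > 50000 nM
Compound 2 `CCCCNC(=O)c1c(N)sc(-c2ccc(Cl)cc2)c1-c1ccc(Cl)cc1`: 17800 nM

Both compounds were tested in a functional assay on PC-3 cells (Homo sapiens) for inhibition, read by sulforhodamine B assay, with a stated time of 72 h; a lower number here means a stronger inhibitor, a higher number a weaker inhibitor. In this assay compound 1 gives > 50000 nM, which is a limit of the assay rather than a number. Compound 2 gives 17800 nM in this assay. Among the measured compounds shown here, the only measured step, an at least 2.8-fold lower number from compound 1 to compound 2 (0.44 log units; beyond the scatter), changed the same group that changes now. Compound 3 `Nc1sc(-c2ccc(Cl)cc2)c(-c2ccc(Cl)cc2)c1C(=O)NCc1ccccc1` differs from compound 1 by benzyl in place of phenyl on an amide-type nitrogen. A lower number is expected because an at least 2.8-fold lower number from compound 1 to compound 2 (0.44 log units; beyond the scatter) came from a similar exchange at that nitrogen. The expected step is an at least 2.5-fold lower number from compound 1 to compound 3 (0.39 log units; beyond the scatter). Compound 3 is estimated at 20000 nM, between 6000 nM and 50000 nM.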

Compound 3, half-maximal inhibitory concentration: 31800 nM
For compound 3 the middle estimate is 1.6-fold (0.20 log units) below the measured one, within the range that was stated.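

Benzyl in place of phenyl on the amide nitrogen gives an at least 1.5-fold lower number from compound 1 to compound 3 (0.19 log units; that floor lies within the scatter), so this exchange alone does not establish a real gain. The true size of that step cannot be read, because it starts from a limit of the assay: the limit of > 50000 nM in this assay, at which 1 of the 3 values shown sits. Set against the butyl amide, the benzyl amide gives a 1.8-fold higher number from compound 2 to compound 3 (0.25 log units; within the scatter), so a phenyl ring carried on a chain carbon and a plain butyl chain cannot be told apart at this nitrogen in this assay.

Still open, going by these compounds, is how a longer chain, or a chain ending in an amine or a carboxylic acid, would read at this nitrogen.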